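A few compounds are considered here, and "the series" means these few. Any claim that something is new, unique, unknown or untested is made for them only; others in the source may bear on it.

Working notes on the series. The shared core of compound 1 `COc1cc(-n2cnc3ccc(-c4ccc(C)cc4F)cc32)cc(OC)c1OC` carries a trimethoxyphenyl group and a variable aryl substituent; in a functional assay on SGC-7901 cells (Homo sapiens) for antiproliferative activity, read by MTT assay, with a stated time of 72 h (on this read-out higher numbers stand for weaker inhibition and lower numbers for stronger inhibition), compound 1 gives 5650 nM. Compound 2 `COc1cc(-n2cnc3ccc(-c4ccccc4)cc32)cc(OC)c1OC` gives 290 nM, and compound 3 `COc1cc(-n2cnc3ccc(-c4cccc(N)c4)cc32)cc(OC)c1OC` gives 21 nM. On these numbers compound 2 stands second highest of the three: the change to compound 3 brought a 14-fold lower number from compound 2 to compound 3 (1.14 log units; beyond the scatter), while compound 1 sits above it by a 19-fold lower number from compound 1 to compound 2 (1.29 log units; beyond the scatter) read in reverse.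

Compound 4 `COc1cccc(-c2ccc3ncn(-c4cc(OC)c(OC)c(OC)c4)c3c2)c1` is not yet measured. Against compound 2 the difference is methoxy in place of hydrogen on an aromatic carbon, sitting on an aromatic carbon of a six-membered aromatic ring of carbon only, meta to a large group; cut one bond further out it reads phenyl to 3-methoxyphenyl.

Going by the values given here, the step that bears most directly is the one from compound 2 to compound 3, where a substituent at the same place gave a 14-fold lower number from compound 2 to compound 3 (1.14 log units; beyond the scatter), a large lowering. Whether a methoxy group, with one hydrogen-bond acceptor and no donor, repeats this is not shown by the measured compounds, so a smaller step in the same direction is expected. Compound 4 is therefore estimated at 120 nM, range 40 nM to 400 nM, meaning an expected step of a 2.4-fold lower number from compound 2 to compound 4 (0.38 log units; beyond the scatter).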

Compound 4, half-maximal inhibitory concentration: 3310 nM
Compound 4: middle estimate off by 28-fold (1.44 log units), on the low side; the whole stated range lies below it.
By their numbers in this assay, from the lowest: compound 3; then compound 2; then compounds 4 and 1 (each within the scatter of the next).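

In this assay, the place on the aromatic carbon meta to a large group proves sensitive in both directions: methoxy in place of hydrogen gives an 11-fold higher number from compound 2 to compound 4 (1.06 log units; beyond the scatter), the opposite direction to the lowering seen with amino, so the direction of change here depends on the group that enters and not merely on the hydrogen being replaced. The exchange of amino for methoxy at this one place spans a 160-fold higher number from compound 3 to compound 4 (2.20 log units; beyond the scatter), the widest step yet seen for a change of a single group on the phenyl ring, while a 1.7-fold lower number from compound 1 to compound 4 (0.23 log units; within the scatter) leaves 3-methoxyphenyl and 2-fluoro-4-methylphenyl unseparated, so that among the substituted rings shown only 3-aminophenyl stands below plain phenyl. No measurement at hand accounts for the reversal between amino and methoxy.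

The compounds shown leave open whether the low number of compound 3 belongs to amino itself or would also appear with hydroxy, methylamino or acetamido at the same place. They also leave open whether amino added to the 2-fluoro-4-methylphenyl ring of compound 1 would lower the number as it does on the phenyl ring of compound 2.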